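The source may hold more compounds than are shown below. What is called first, only, known or untested is meant among the compounds shown, and "the series" means these compounds.

Three compounds here share one core and differ only in the group on the amide-type nitrogen. Compound 1 `CNC(=O)c1cc(-c2ccc(F)cc2F)ccc1OC(C)=O` carries a methyl there, and in a functional assay on the whole organism (Ear) for inhibition, with Mus musculus as the target, at a dose of 40 mg/kg by the oral route (a higher number here means more inhibition at the dose given (going by the name of the read-out), a lower number less inhibition), compound 1 gives 48.8%. Compound 2 `CCNC(=O)c1cc(-c2ccc(F)cc2F)ccc1OC(C)=O` carries an ethyl, and in this assay compound 2 gives 5.38%. Compound 3 `CC(=O)Oc1ccc(-c2ccc(F)cc2F)cc1C(=O)Nc1cccc(C)c1` carries a 3-methylphenyl, and in this assay compound 3 gives 12.8%. Among the three numbers compound 3 stands second highest: its nearest neighbour is compound 2, within the scatter, and its furthest is compound 1, beyond it.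

Compound 4 `CC(=O)Oc1ccc(-c2ccc(F)cc2F)cc1C(=O)Nc1ccc(Cl)cc1` has not been measured. It differs from compound 3 in one place: 4-chlorophenyl in place of 3-methylphenyl on an amide-type nitrogen. Two measured steps change the same nitrogen substituent. a number 36 percentage points lower from compound 1 to compound 3 (beyond the scatter), while a number 7.4 percentage points higher from compound 2 to compound 3 (within the scatter). Among the compounds with values here, neither step exchanges one aromatic ring for another, so no measured step shows what such a swap does. For compound 4 the expected step is a number 1.2 percentage points higher from compound 3 to compound 4 (within the scatter), within the scatter. Compound 4 is estimated at 14%, with a range from 0% to 35%.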

Compound 4, a percentage reported as inhibition, in the whole organism at one dose (the size of the read-out at that dose, not a potency): 0%
Compound 4: the middle estimate sits 14 percentage points above what was measured; the measured number falls inside the stated range.
By their numbers in this assay, from the lowest: compounds 4, 2 and 3 (each within the scatter of the next, the first and the last beyond it); then compound 1.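

Within the data shown here, this change is the first exchange of one aromatic ring for another on the amide-type nitrogen, and in this assay it shifts the read-out beyond the scatter (a number 12.8 percentage points lower from compound 3 to compound 4 (beyond the scatter)), even though 3-methylphenyl and 4-chlorophenyl have the same count of heavy atoms. Against ethyl, the 4-chlorophenyl group makes no clear difference (a number 5.4 percentage points lower from compound 2 to compound 4 (within the scatter)), but against methyl the gap is the widest in the set (a number 48.8 percentage points lower from compound 1 to compound 4 (beyond the scatter)), so all three other groups now stand well under the methyl of compound 1. Nothing given here explains these differences.

Compound 3 and compound 4 differ in both the ring substituent and where it sits, so those two changes cannot be separated. A 3-chlorophenyl or a plain phenyl group would help to separate them, while the amide hydrogen in place of methyl would test the other end of the series.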